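Capping the Hydroxyl: From Compound 1 to Compound 3

The source may report more compounds than this note shows. Statements on the series, on what has been measured and on what is new or still open speak of the compounds shown alone.

Compound 1 `O=C(NCCO)c1cccc(-c2cccc3cc(Cc4cccc(C(F)(F)F)c4)sc23)c1` gives 37.2 nM in a functional assay on CHO cells for agonist activity at G-protein coupled receptor 52 (Homo sapiens), read by AlphaScreen and cAMP accumulation, with a stated time of 30 min; on this read-out higher numbers stand for an effect only at larger amounts of compound and lower numbers for an effect already at smaller amounts. Compound 2 `O=C(NCCO)c1cccc(-c2cccc3cn(Cc4cccc(C(F)(F)F)c4)nc23)c1` gives 64.6 nM in this assay, and the two numbers lie within the scatter of each other, so neither compound stands apart. Compound 3 `COCCNC(=O)c1cccc(-c2cccc3cc(Cc4cccc(C(F)(F)F)c4)sc23)c1` has not yet been measured. It differs from compound 1 by methyl in place of hydrogen on an oxygen on a saturated carbon. Within the data shown here, no measured pair shows this exact change, so the expectation rests on compound 1 alone: a step of a 1.3-fold higher number from compound 1 to compound 3 (0.13 log units; within the scatter) is expected, not beyond the scatter in either direction. Compound 3 is estimated at 50 nM, within 15 nM to 160 nM.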

Compound 3, half-maximal effective concentration: 42.7 nM
Compound 3: the middle estimate sits 1.2-fold (0.07 log units) above what was measured, within the range that was stated.
By their numbers in this assay, from the lowest: compounds 1, 3 and 2 (each within the scatter of the next).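

Capping the hydroxy group as methoxy gives a 1.1-fold higher number from compound 1 to compound 3 (0.06 log units; within the scatter) in this assay. At this oxygen, then, a methyl can take the place of the hydrogen with no shift beyond the scatter, so the 2-hydroxyethyl chain need not end in a free hydroxy group for this level of agonist activity to remain. The data at hand give no reason for this result.

Going by these compounds, whether an amine or a carboxylic acid at the end of the chain would leave the number as little changed remains open. So does the effect of a longer chain.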